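Phenylsulfonyl to (4-bromophenyl)sulfonyl in compound 2

This account rests on a few compounds, and the source may have more. Where it says the series, first, only, none or still open, it means among the compounds named here.

In a functional assay on SMMC-7721 cells (Homo sapiens) for cytotoxicity, read by MTT assay, with a stated time of 24 h (on this read-out lower numbers stand for stronger inhibition and higher numbers for weaker inhibition), compound 1 (`COc1cc(/C=C2\CN(C)C/C(=C\c3ccncc3)C2=O)cc(OC)c1OC`) gives 9130 nM and compound 2 (`O=C1/C(=C/c2cccnc2)CN(S(=O)(=O)c2ccccc2)C/C1=C\c1ccccc1F`) gives 19100 nM as the higher of the two numbers, a gap beyond the scatter. Compound 3 (`O=C1/C(=C/c2cccnc2)CN(S(=O)(=O)c2ccc(Br)cc2)C/C1=C\c1ccccc1F`) differs from compound 2 by bromo in place of hydrogen on an aromatic carbon as bromo in place of hydrogen on an aromatic carbon, para to a large group. Going by the values given here, no measured pair shows this change, so only a small move is expected. The expected step is a 1.6-fold lower number from compound 2 to compound 3 (0.20 log units; within the scatter) and it stays within the scatter. In this assay the estimate for compound 3 is 12000 nM with 5000 nM and 28000 nM as its expected bounds.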

Compound 3, half-maximal inhibitory concentration: 9100 nM
Beside the measured number, compound 3's estimate is 1.3-fold (0.12 log units) above it; the measured number falls inside the stated range.
By their numbers in this assay, from the lowest: compounds 3 and 1 (each within the scatter of the next); then compound 2.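

In this assay, going by these compounds alone, phenylsulfonyl to (4-bromophenyl)sulfonyl gives a 2.1-fold lower number from compound 2 to compound 3 (0.32 log units; beyond the scatter), a modest step and the first single-place comparison. It shows that the number responds to a change at this aromatic carbon, para to a large group, which compounds 1 and 2 alone could not show. No available evidence bears on the reason for this step.

Going by these compounds, whether chloro, methoxy or an amine on the same carbon would move the number in the same direction remains open. Also open, on these data alone, is whether bromo gives a similar step with other arylidene groups on the shared core.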